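Adding a carboxy group to compound 1

The source may hold more compounds than are shown below. What is called first, only, known or untested is meant among the compounds shown, and "the series" means these compounds.

In a functional assay on Huh-5-2 cells (Homo sapiens), read by MTT assay (a higher number here means that more compound is tolerated, a lower number that less compound is tolerated), compound 1 (`O=C(O)c1ccc2c(c1)nc(-c1ccc(OCc3ccccc3-c3ccc(Cl)cc3)cc1)n2C1CCCCC1`) gives 25000 nM and lies within the scatter of both other measured compounds. Compound 2 (`COc1ccc(-c2ccc(Cl)cc2)c(COc2ccc(-c3nc4cc(C(=O)O)ccc4n3C3CCCCC3)cc2)c1`) gives 24000 nM and compound 3 (`CN(C)c1ccc(-c2ccc(Cl)cc2)c(COc2ccc(-c3nc4cc(C(=O)O)ccc4n3C3CCCCC3)cc2)c1`) gives 30000 nM on the same scale. Within the data shown here, compound 4 (`O=C(O)c1ccc(-c2ccc(Cl)cc2)c(COc2ccc(-c3nc4cc(C(=O)O)ccc4n3C3CCCCC3)cc2)c1`) has no measurement yet.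

The structural change under review is carboxy in place of hydrogen on an aromatic carbon and the new carboxy stands para to a 4-chlorophenyl group.

The closest evidence comes from compound 2 and compound 3, which carry their added groups at the same place. Methoxy in place of hydrogen gives a 1.0-fold lower number from compound 1 to compound 2 (0.02 log units; within the scatter) and dimethylamino in place of hydrogen gives a 1.2-fold higher number from compound 1 to compound 3 (0.08 log units; within the scatter) while dimethylamino in place of methoxy gives a 1.3-fold higher number from compound 2 to compound 3 (0.10 log units; within the scatter) and each of these steps stays within the scatter. This place has so far tolerated two different groups with no measurable shift, but only these three compounds support that reading. Among the measured compounds shown here, no measured compound carries a carboxy there, so the extrapolation to compound 4 remains uncertain and the range is kept wide.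

The estimated step is a 1.2-fold higher number from compound 1 to compound 4 (0.08 log units; within the scatter) and no change beyond the scatter is expected in either direction. Compound 4 is expected at 30000 nM with an estimated range of 15000 nM to 60000 nM in this assay.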

Compound 4, half-maximal cytotoxic concentration: > 50000 nM
Compound 4: a limit, no number; the forecaster's own chance of this, stated with the estimate: 20%; at least 1.6-fold (0.22 log units) between middle value and limit.
By their numbers in this assay, from the lowest: compounds 2, 1 and 3 (each within the scatter of the next). At a limit, above all of these: compound 4.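

In this assay compound 4 gives > 50000 nM, which is a limit of the assay and not a number: the limit of > 50000 nM in this assay, at which 1 of the 4 values shown sits. Among these compounds, of the three steps into compound 4, only carboxy in place of methoxy, with an at least 2.0-fold higher number from compound 2 to compound 4 (0.31 log units; beyond the scatter), is printed as beyond the scatter, and it is the first step at this position, para to a 4-chlorophenyl group, to clear it, so this place is no longer one where every change has left the number within the scatter. The other two steps are less firm, since carboxy in place of hydrogen gives an at least 2.0-fold higher number from compound 1 to compound 4 (0.30 log units; that floor lies within the scatter) and carboxy in place of dimethylamino gives an at least 1.6-fold higher number from compound 3 to compound 4 (0.22 log units; that floor lies within the scatter), and the floors of both lie within the scatter, so compound 4 is separated clearly from compound 2 only.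

As far as these compounds go, how far compound 4 lies past its limit stays open, and with it the true size of all three steps. Also open, from the compounds shown here alone, is whether the upward step belongs to carboxy alone or would also appear with a primary amide, a hydroxy group or a longer chain ending in a carboxylic acid at this place.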